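The compounds below may be only part of what the source reports. "The series", "measured", "known", "first", "only" and "open" are said of these compounds alone.

Compound 1 `Cc1c(OCCCCOc2ccc(C(=O)O)cc2)ccc(C(=O)CC2CCCC2)c1O` and compound 2 `Cc1c(OCCCCOc2ccc(C(=O)O)cc2)ccc(C(=O)CC(C)C)c1O` share one core and were both read in an assay on HEK293 cells for positive allosteric modulation of metabotropic glutamate receptor 2 (Rattus norvegicus), read by thallium flux, with a stated time of 2.5 min; on this read-out lower numbers stand for smaller maximal responses and higher numbers for larger maximal responses. In that assay compound 1 gives 82.6% and compound 2 gives 88%, the step being a number 5.4 percentage points higher from compound 1 to compound 2 (within the scatter), which changes an isopropyl for a cyclopentyl on a saturated chain carbon bound to a carbonyl carbon; compound 1 thus stands nearest compound 2 and the two numbers cannot be told apart. Compound 3 `Cc1cc(OCCCCOc2ccc(C(=O)CC3CCCC3)c(O)c2C)ccc1C(=O)O` has not been measured. It differs from compound 1 by methyl in place of hydrogen on an aromatic carbon. Among the measured compounds shown here, no measured step touches this kind of change: the only step at hand concerns the group bound to the carbonyl, not the ring bearing the carboxy group, and it was within the scatter. On that basis the step expected in this assay is a number 0.6 percentage points lower from compound 1 to compound 3 (within the scatter), nothing beyond the scatter. Compound 3 is therefore estimated at 82%, with a range from 65% to 100%.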

Compound 3, largest response reached (reported as percent of maximum), in percent of the reference or control that the assay uses: 83.6%
The estimate for compound 3 lay 1.6 percentage points below the measured number, and the stated range covers the measured number.
By their numbers in this assay, from the lowest: compounds 1, 3 and 2 (each within the scatter of the next).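

The change on the ring bearing the carboxy group now has a reading of its own: in this assay, methyl in place of hydrogen on an aromatic carbon, ortho to a carboxy group, gives a number 1 percentage points higher from compound 1 to compound 3 (within the scatter). On the core of compound 1, this position therefore accepts the methyl with no change in maximal response that can be told from the scatter. No evidence here explains this result.

From the compounds shown here alone, it remains open whether a different group at this position, such as chlorine, methoxy or an amine, would move the maximal response beyond the scatter. Also open, going by these compounds, are whether the methyl would behave the same way alongside the isopropyl of compound 2, and what an amide or a tetrazole in place of the carboxy group would give.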